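The source may report more compounds than this note shows. Statements on the series, on what has been measured and on what is new or still open speak of the compounds shown alone.

Measured so far:
- Compound 1, `CCCOc1ccc(NC(=O)CSc2nnc(Cc3nn(C)c(=O)c4ccccc34)n2C)cc1`: > 30000 nM in an assay on isolated protein (Mus musculus) for inhibition of IL15-IL15 receptor (Homo sapiens), read by resazurin assay, with stated times of 30 min and 2.5 days; on this read-out higher numbers stand for weaker inhibition and lower numbers for stronger inhibition
- Compound 2, `CC(C)COc1ccc(NC(=O)CSc2nnc(Cc3nn(C)c(=O)c4ccccc34)n2C)cc1`: 30000 nM
- Compound 3, `COc1ccc(NC(=O)CSc2nnc(Cc3nn(C)c(=O)c4ccccc34)n2C)cc1`: "not active" (no number reported)

All three share one core and differ only in the group on the amide-type nitrogen. The value of compound 1 is a limit of this assay, not a number (the limit of > 30000 nM in this assay, at which 1 of the 3 values shown sits). For the measured compounds named here, compound 2 gives the one plain number, 30000 nM, at the weak end of the scale. The step of a number no higher from compound 1 to compound 2 (the limit leaves the size open) therefore has no readable size. Compound 3 is reported only as "not active" (no number reported), without a number, so it stands with the others at the weak end, with nothing to rank it against compound 2.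

Compound 4, `Cn1c(Cc2nn(C)c(=O)c3ccccc23)nnc1SCC(=O)Nc1ccc(F)cc1F`, changes the same nitrogen: 2,4-difluorophenyl in place of 4-methoxyphenyl on an amide-type nitrogen. Going by the values given here, no measured step swaps the whole aryl group this way; the only measured step, a number no higher from compound 1 to compound 2 (the limit leaves the size open), alters a saturated chain carbon and is unreadable in size. No shift beyond the scatter is expected. Compound 4 is estimated at 30000 nM, within 10000 nM to 100000 nM, and most likely only a limit will be reported.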

Compound 4, half-maximal inhibitory concentration: "not active" (no number reported)
Compound 4: no number reported; there is nothing to compare the estimate with.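

Compound 3 and compound 4 are both reported only as "not active", without a number, so no step can be read from this change of aryl group. The compounds shown leave open whether any group on the amide-type nitrogen gives clear inhibition in this assay.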